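Hepatocyte clearance notes: carbamoyl, cyano and fluoro analogues

A few compounds are considered here, and "the series" means these few. Any claim that something is new, unique, unknown or untested is made for them only; others in the source may bear on it.

Compound 1 `C[C@H](Oc1cc2cc(C(N)=O)ccc2nc1N)c1cc(F)c(F)cc1-n1cccn1` carries a carbamoyl group on the shared core; in an ADME assay on cells (Hepatocyte, Homo sapiens) for metabolic stability (on this read-out higher numbers stand for fast clearance and lower numbers for slow clearance), compound 1 gives 14 uL/min. Compound 2 `C[C@H](Oc1cc2cc(C#N)ccc2nc1N)c1cc(F)c(F)cc1-n1cccn1` is the cyano analogue; in this assay compound 2 gives 24 uL/min. Within the data shown here, the one measured step, a 1.7-fold higher number from compound 1 to compound 2 (0.23 log units; within the scatter), shows no movement beyond the scatter. Among the measured compounds shown here, on the two numbers so far compound 2 stands highest, with compound 1 nearest and within the scatter of it, so no order between the two can be claimed.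

Compound 3 `C[C@H](Oc1cc2cc(F)ccc2nc1N)c1cc(F)c(F)cc1-n1cccn1` brings the next change: fluoro in place of cyano on an aromatic carbon. For the measured compounds named here, only the step from compound 1 to compound 2 bears on this, and that step stayed within the scatter, so nothing beyond the scatter is expected in this assay. The expected step is therefore small: a 1.0-fold higher number from compound 2 to compound 3 (0.02 log units; within the scatter). Compound 3 is estimated at 25 uL/min, with a range of 12 uL/min to 50 uL/min.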

Compound 3, intrinsic clearance in a liver preparation (reported as CLH), per the amount of preparation that the assay uses in the Hepatocyte assay: 57 uL/min
For compound 3 the middle estimate is 2.3-fold (0.36 log units) below the measured one; the whole stated range lies below it.
By their numbers in the Hepatocyte assay, from the lowest: compounds 1 and 2 (each within the scatter of the next); then compound 3.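

In the Hepatocyte assay this aromatic position now shows a real response to the group it carries: a 2.4-fold higher number from compound 2 to compound 3 (0.38 log units; beyond the scatter) and a 4.1-fold higher number from compound 1 to compound 3 (0.61 log units; beyond the scatter), whereas the earlier exchange of carbamoyl for cyano stayed within the scatter. In a physicochemical assay for lipophilicity, using the shake flask method (on this read-out higher numbers stand for higher lipophilicity and lower numbers for lower lipophilicity), compound 2 gives 4.3 and compound 3 gives 4.1, with a number 0.20 log units lower from compound 2 to compound 3 (within the scatter), so the clearance step is not matched by a distribution coefficient step beyond the scatter. Nothing available accounts for the clearance step between the cyano and fluoro compounds.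

Going by these compounds, whether the higher clearance number is specific to fluoro remains open, and chloro, methoxy or an amine on the same aromatic carbon would test this. On these data alone, it also remains open whether the same order of groups would hold on a core with a different substitution elsewhere.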